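Swapping Methoxy for Methoxycarbonyl on a Weakly Cytotoxic Scaffold

This account rests on a few compounds, and the source may have more. Where it says the series, first, only, none or still open, it means among the compounds named here.

Compound 1 `COc1ccc(C2=C(c3cc(OC)c(OC)c(OC)c3)C(=O)CC2O[SiH2]C(C)(C)C)cc1OC` was tested in an ADME assay on DU-145 cells (Homo sapiens) for cytotoxicity, read by MTT assay, with a stated time of 72 h; a higher number here means a weaker inhibitor, a lower number a stronger inhibitor. Compound 1 gives only a limit there, > 100 ug/mL, and no number is known for it. Compound 3 `COc1ccc(C2=C(c3cc(OC)c(OC)c(OC)c3)CC(O)C2=O)cc1[N+](=O)[O-]` likewise gives only a limit in this assay, > 100 ug/mL. Compound 2 `COc1ccc(C2=C(c3cc(OC)c(OC)c(OC)c3)C(=O)C(OC(C)=O)C2)cc1Cl` gives a number in this assay, 64 ug/mL. Compound 1 thus stands at the limit of > 100 ug/mL in this assay, at which 2 of the 3 values shown sit, where nothing separates it from compound 3, while compound 2 alone gives a measurable value. Compound 4 `COC(=O)c1cc(C2=C(c3cc(OC)c(OC)c(OC)c3)C(=O)CC2O[SiH2]C(C)(C)C)ccc1OC` has not yet been measured; it differs from compound 1 by methoxycarbonyl in place of methoxy on an aromatic carbon. Among the measured compounds shown here, no measured pair shows a change of this kind, and the expected step is small, a number no higher from compound 1 to compound 4 (the limit leaves the size open), none beyond the scatter. Compound 4 is expected to give about 100 ug/mL, with a likely range from 40 ug/mL to 300 ug/mL.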

Compound 4, half-maximal inhibitory concentration: > 100 ug/mL
Compound 4: only a limit was reported (the forecaster's own chance of this, stated with the estimate: 60%); the middle value sits exactly at the limit.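

Compound 1 and compound 4 each give only a limit in this assay, so no step can be read between them. The compounds shown leave open whether methoxycarbonyl in place of methoxy changes cytotoxicity at all, and by how much.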